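The compounds below may be only part of what the source reports. "The series", "measured", "known", "first", "only" and "open" are said of these compounds alone.

In an assay on HEK-293T cells for inhibition of diacylglycerol lipase-alpha (Homo sapiens), read by colorimetric assay (a higher number here means a weaker inhibitor, a lower number a stronger inhibitor), compound 1, with the structure `CC(=O)c1coc(C(=O)CCCCCCc2ccccc2)n1`, gives 123 nM. Compound 2, with the structure `COc1coc(C(=O)CCCCCCc2ccccc2)n1`, carries a methoxy where compound 1 carries an acetyl. In this assay compound 2 gives only a limit of the assay, > 10000 nM. That change is an at least 81-fold higher number from compound 1 to compound 2 (1.91 log units; beyond the scatter). Compound 3, with the structure `COc1cnc(C(=O)CCCCCCc2ccccc2)o1`, also gives only a limit in this assay, > 10000 nM. The step that the two limits leave unreadable from compound 2 to compound 3 can therefore not be read. Compound 2 thus stands at the limit of > 10000 nM in this assay, at which 2 of the 3 values shown sit, with no number of its own.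

Compound 4, with the structure `O=C(CCCCCCc1ccccc1)c1nc(-c2ccncc2)co1`, differs from compound 2 by pyridin-4-yl in place of methoxy on an aromatic carbon. Going by the values given here, the only readable step that touches this position is the one from acetyl to methoxy, an at least 81-fold higher number from compound 1 to compound 2 (1.91 log units; beyond the scatter), which runs in the opposite direction and was large. Putting a larger group back at the same carbon is therefore expected to lower the number again, an estimated step of an at least 25-fold lower number from compound 2 to compound 4 (1.39 log units; beyond the scatter). Compound 4 is expected to give 400 nM in this assay, somewhere between 60 nM and 6000 nM.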

Compound 4, half-maximal inhibitory concentration: > 10000 nM
Compound 4 gave a limit, no number (the forecaster's own chance of this, stated with the estimate: 20%); middle value at least 25-fold (1.39 log units) from the limit.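

Replacing the acetyl with pyridin-4-yl gives an at least 81-fold higher number from compound 1 to compound 4 (1.91 log units; beyond the scatter). A group larger than methoxy at this carbon therefore does not by itself restore what the acetyl of compound 1 gave, and in this assay both replacements of the acetyl now end at a limit rather than a number: the limit of > 10000 nM in this assay, at which 3 of the 4 values shown sit. The step between compound 2 and compound 4 cannot be read, so neither of them can be placed ahead of the other.

The compounds shown leave open whether the carbonyl of the acetyl is what matters at this carbon, which a methyl ester, an amide or a carboxylic acid there could test. They also leave open whether a pyridine joined through a different ring carbon, or a plain phenyl, would behave like pyridin-4-yl.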